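Benzylselanyl for methylsulfanyl on the bis-amide central carbon

A few compounds are considered here, and "the series" means these few. Any claim that something is new, unique, unknown or untested is made for them only; others in the source may bear on it.

Working notes on a small set of symmetric diacyl isoselenourea and isothiourea compounds tested in a functional assay on K562 cells (Homo sapiens) for cytotoxicity, read by MTT assay, with a stated time of 72 h; on this read-out higher numbers stand for weaker inhibition of growth and lower numbers for stronger inhibition of growth.

Compound 1 `C[Se]/C(=N\C(=O)c1cccs1)NC(=O)c1cccs1` carries two thiophene amides on a methylselanyl core. In this assay compound 1 reaches only the limit of the measurement, > 100000 nM. Compound 2 `C[Se]/C(=N\C(=O)c1cnc2ccccc2c1)NC(=O)c1cnc2ccccc2c1`, with two quinoline amides on the same methylselanyl core, gives 29900 nM in this assay. Compound 3 `CS/C(=N\C(=O)c1csc([N+](=O)[O-])c1)NC(=O)c1csc([N+](=O)[O-])c1`, two nitrothiophene amides on a methylsulfanyl core, gives 98700 nM in this assay. Of the two numbers shown, compound 3 stands highest; compound 2 lies lower, by a gap beyond the usual scatter, and the one further value is a limit (the limit of > 100000 nM in this assay, at which 1 of the 3 values shown sits).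

Compound 4 `O=C(/N=C(/NC(=O)c1csc([N+](=O)[O-])c1)[Se]Cc1ccccc1)c1csc([N+](=O)[O-])c1` keeps the nitrothiophene amides of compound 3 and changes only the group on the central carbon: a group of 8 heavy atoms (7 carbon, 1 selenium; one six-membered aromatic ring of carbon only) in place of a group of 2 heavy atoms (1 carbon, 1 sulfur; no ring), on a carbon with a double bond to nitrogen. Among the compounds with values here, no pair measured here separates this change alone, so no measured step supports an expectation of direction. The expected step from compound 3 to compound 4 is a 2.0-fold lower number from compound 3 to compound 4 (0.30 log units; within the scatter), a modest lowering at the edge of the scatter. Compound 4 is therefore estimated at 50000 nM in this assay, with a range from 15000 nM to 150000 nM.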

Compound 4, concentration for total growth inhibition: 55800 nM
The estimate for compound 4 lay 1.1-fold (0.05 log units) below the measured number; low and high end bracket the measured number.
By their numbers in this assay, from the lowest: compounds 2, 4 and 3 (each within the scatter of the next, the first and the last beyond it). At a limit, above all of these: compound 1.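

The step in this assay is a 1.8-fold lower number from compound 3 to compound 4 (0.25 log units; within the scatter) and so cannot be told from scatter: on a carbon with a double bond to nitrogen whose other neighbours are the two amide-type nitrogens, methylsulfanyl gives way to a far larger group with no measurable change in growth inhibition. Within the data shown here, compound 3 and compound 4 form the first pair that differs in one place, so this is the first direct reading of this position, which the earlier compounds could not give. The change replaces sulfur with selenium and also adds a six-membered aromatic ring of carbon only, so this single step cannot separate the two parts.

Still open, from the compounds shown here alone, is how the nitrothiophene amides behave with methylselanyl on the central carbon, which would part the selenium from the ring, or with a longer chain such as butyl or with an amine in the same place. Nothing in the evidence at hand bears on this step or gives a reason for its size.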